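Thiophene attachment swap at the weak end of the series

This account rests on a few compounds, and the source may have more. Where it says the series, first, only, none or still open, it means among the compounds named here.

In a functional assay on cells (Cancer cell lines, Homo sapiens) for inhibition (on this read-out higher numbers stand for weaker inhibition of growth and lower numbers for stronger inhibition of growth), compound 1 `Cc1cc(-c2nc3sc(C)cn3c2/C=N/NC(=N)N)c(C)s1` gives 3720 nM and compound 2 `Cc1cn2c(/C=N/NC(=N)N)c(-c3ccsc3)nc2s1` gives 5370 nM while compound 3 `N=C(N)N/N=C/c1c(-c2ccsc2)nc2sccn12` gives 14100 nM and stands as the weakest of the three. Compound 4 `N=C(N)N/N=C/c1c(-c2cccs2)nc2sccn12` has the same atoms as compound 3, joined differently (thiophen-2-yl in place of thiophen-3-yl on an aromatic carbon) with thiophen-2-yl in place of thiophen-3-yl on an aromatic carbon. Among the compounds with values here, no measured step makes this exact change. The closest one, with thiophen-3-yl in place of 2,5-dimethylthiophen-3-yl, gives a 1.4-fold higher number from compound 1 to compound 2 (0.16 log units; within the scatter) and so a change to that group has moved the number little. The other step, with hydrogen in place of methyl on an aromatic carbon of the core, gives a 2.6-fold higher number from compound 2 to compound 3 (0.42 log units; beyond the scatter) and concerns a different place. In this assay the step of a 1.2-fold lower number from compound 3 to compound 4 (0.07 log units; within the scatter) is therefore expected to stay within the scatter, with no firm direction. Compound 4 is estimated at 12000 nM (expected range 5500 nM to 26000 nM).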

Compound 4, concentration for 50% growth inhibition: 9770 nM
Beside the measured number, compound 4's estimate is 1.2-fold (0.09 log units) above it; low and high end bracket the measured number.
By their numbers in this assay, from the lowest: compounds 1, 2, 4 and 3 (each within the scatter of the next, the first and the last beyond it).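

Notes on the thiophene position: in this assay, thiophen-2-yl in place of thiophen-3-yl gives a 1.4-fold lower number from compound 3 to compound 4 (0.16 log units; within the scatter), so on the core lacking the methyl, the two attachment isomers at this aromatic carbon next to the ring nitrogen are not told apart. Within the data shown here, with a 1.4-fold higher number from compound 1 to compound 2 (0.16 log units; within the scatter), this makes a second change to the thiophene that stays within the scatter, while the one single-place step beyond it remains a 2.6-fold higher number from compound 2 to compound 3 (0.42 log units; beyond the scatter), which lies on the core rather than at this position. No available data bear on why the two thiophene isomers read alike.

Going by these compounds, whether thiophen-2-yl reads the same with the core methyl of compound 2 present remains open. Also open, on these data alone, is how a phenyl group or an amine would read at this position.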